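The source may report more compounds than this note shows. Statements on the series, on what has been measured and on what is new or still open speak of the compounds shown alone.

Measured compounds in the series:

compound 1, `C[Se]/C(=N\C(=O)c1cc2ccccc2s1)NC(=O)c1cc2ccccc2s1`, 37200 nM
compound 2, `CS/C(=N\C(=O)c1cc2ccccc2s1)NC(=O)c1cc2ccccc2s1`, 8580 nM
compound 3, `CS/C(=N\C(=O)c1cc(-c2ccccc2)nc2ccccc12)NC(=O)c1cc(-c2ccccc2)nc2ccccc12`, 7480 nM

All three were run in a functional assay on PC-3 cells (Homo sapiens) for cytotoxicity, read by MTT assay, with a stated time of 72 h; on this read-out lower numbers stand for stronger inhibition of growth and higher numbers for weaker inhibition of growth. Compound 1 and compound 2 share a core and differ only in the group on the carbon with a double bond to nitrogen: a group of 2 heavy atoms (1 carbon, 1 selenium; no ring) in place of a group of 2 heavy atoms (1 carbon, 1 sulfur; no ring), on a carbon with a double bond to nitrogen. The step is a 4.3-fold higher number from compound 2 to compound 1 (0.64 log units; beyond the scatter), so the selenium-bearing group gives the weaker result on this pair.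

Compound 3 carries a different core; how its core differs from that of compound 2 is not broken down here. In this assay compound 3 gives 7480 nM, and its number and that of compound 2 lie within the usual scatter of one another, so no order between them is claimed.

Compound 4, `C[Se]/C(=N\C(=O)c1cc(-c2ccccc2)nc2ccccc12)NC(=O)c1cc(-c2ccccc2)nc2ccccc12`, is not yet measured. It differs from compound 3 in the same way that compound 1 differs from compound 2: a group of 2 heavy atoms (1 carbon, 1 selenium; no ring) in place of a group of 2 heavy atoms (1 carbon, 1 sulfur; no ring), on a carbon with a double bond to nitrogen. The place of the change is described in the same words for both pairs, so this is taken as the same change on a second core.

Among the measured compounds shown here, for compound 4 a step of about a 4.3-fold higher number from compound 3 to compound 4 (0.63 log units; beyond the scatter) is expected, resting on the one earlier instance of this change, the step of a 4.3-fold higher number from compound 2 to compound 1 (0.64 log units; beyond the scatter), applied to the value of compound 3, 7480 nM. For the measured compounds named here, with only one prior example, the expected step is given a wide range. The estimate for compound 4 in this assay is 32000 nM, within 12000 nM to 85000 nM.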

Compound 4, concentration for 50% growth inhibition: 3970 nM
Compound 4: the middle estimate sits 8.1-fold (0.91 log units) above what was measured; measured number outside the range, below it.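

In this assay the selenium-bearing group in place of methylsulfanyl, on a carbon with a double bond to nitrogen, gives a 1.9-fold lower number from compound 3 to compound 4 (0.28 log units; within the scatter), so compound 3 and compound 4 cannot be told apart and the step seen on the core of compound 2 does not carry over to this second core. Set side by side, the two instances of the change do not agree: the same change on two cores in this assay, a 4.3-fold higher number (0.64 log units; beyond the scatter) from compound 2 to compound 1 and a 1.9-fold lower number (0.28 log units; within the scatter) from compound 3 to compound 4, 8.2-fold (0.91 log units) apart, beyond the scatter of two such steps. For these two cores, this shows that a step read on one core is no safe basis for a number on the other; it does not show which part of the cores matters, and with a single pair on each core it gives no general rule for the series.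

The compounds shown leave open how a longer chain, such as ethyl in place of the methyl on the sulfur or selenium, or an amine on the same carbon, would read on each of the two cores. They also leave open whether a third core would follow the pair of compound 1 and compound 2, the pair of compound 3 and compound 4, or neither.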